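The compounds below may be only part of what the source reports. "The series", "measured", "known", "first", "only" and "open" are said of these compounds alone.

Three compounds have been measured in a functional assay on HEK293 cells for agonist activity at Bombesin receptor subtype-3 (Mus musculus), read by luminescence and calcium flux, with a stated time of 10 min; a lower number here means that less compound is needed, a higher number that more compound is needed for the effect:
compound 1 `CCC(C)(C)Cc1c[nH]c(CCc2ccc(-n3ncnn3)cc2)n1` gives 25 nM;
compound 2 `CCC(C)(C)Cc1c[nH]c(CCc2ccc(-c3cnccn3)cc2)n1` gives 11 nM;
compound 3 `CCC(C)(C)Cc1c[nH]c(CCc2ccc(-n3cncn3)cc2)n1` gives 12 nM.

Among these, compound 3 lies close to compound 2 and apart from compound 1: the step of a 2.1-fold lower number from compound 1 to compound 3 (0.32 log units; beyond the scatter) is beyond the scatter, while a 1.1-fold higher number from compound 2 to compound 3 (0.04 log units; within the scatter) is within it. Compound 4 `CCC(C)(C)Cc1c[nH]c(CCc2ccc(N3CCCCC3)cc2)n1` differs from compound 3 in one place: piperidin-1-yl in place of 1H-1,2,4-triazol-1-yl on an aromatic carbon. The measured steps each swap one small aromatic ring for another and are modest at most; none exchanges an aromatic ring for a saturated ring, so they guide only loosely here. A modest shift in this assay, in either direction, seems plausible, with wide uncertainty. Compound 4 is therefore estimated at 20 nM (range 6 nM to 70 nM), which means an expected step of a 1.7-fold higher number from compound 3 to compound 4 (0.22 log units; within the scatter).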

Compound 4, half-maximal effective concentration: 28 nM
Compound 4: middle estimate off by 1.4-fold (0.15 log units), on the low side; the range from low to high includes it.
By their numbers in this assay, from the lowest: compounds 2 and 3 (each within the scatter of the next); then compounds 1 and 4 (each within the scatter of the next).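

Among these compounds, compound 4 is the only compound here with a non-aromatic ring at this position, and it still acts in this assay, so an aromatic ring is not required there. Piperidin-1-yl gives a 2.3-fold higher number from compound 3 to compound 4 (0.37 log units; beyond the scatter) and a 2.5-fold higher number from compound 2 to compound 4 (0.41 log units; beyond the scatter), both modest, while a 1.1-fold higher number from compound 1 to compound 4 (0.05 log units; within the scatter) leaves it level with the 2H-tetrazol-2-yl group. No measured evidence accounts for these differences. On these data alone, whether a morpholin-4-yl ring or an open-chain dimethylamino group would behave like piperidin-1-yl remains open.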